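Removing a ring methyl from a weak antiproliferative scaffold

This account rests on a few compounds, and the source may have more. Where it says the series, first, only, none or still open, it means among the compounds named here.

Measured compounds:
compound 1 `Cc1nsc2[nH]cnc12`: 20000 nM
compound 2 `CSc1nc2c(C)nsc2[nH]1`: 60000 nM

In a functional assay on KB cells (Homo sapiens) for antiproliferative activity (a higher number here means a weaker inhibitor, a lower number a stronger inhibitor), compound 1 gives 20000 nM and compound 2 gives 60000 nM. Going by the values given here, compound 2 thus carries the highest of the two numbers, with compound 1 the nearer and the only neighbour, the single known step being a 3.0-fold higher number from compound 1 to compound 2 (0.48 log units; beyond the scatter). Compound 3 `CSc1nc2cnsc2[nH]1` has not been measured; it differs from compound 2 by hydrogen in place of methyl on an aromatic carbon. Among the compounds with values here, the one measured step concerns a methylsulfanyl substituent on a different carbon, so no measured step bears on the loss of this methyl. With nothing to point either way, the change from compound 2 to compound 3 is expected to stay within the scatter in this assay, and the step is estimated as no change at the digits printed from compound 2 to compound 3 (within the scatter). For compound 3 the expected value in this assay is 60000 nM, with a range from 20000 nM to 180000 nM.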

Compound 3, half-maximal inhibitory concentration: 15000 nM
Compound 3: the middle estimate sits 4.0-fold (0.60 log units) above what was measured; measured number below the stated range.
By their numbers in this assay, from the lowest: compounds 3 and 1 (each within the scatter of the next); then compound 2.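

In this assay, hydrogen in place of methyl gives a step beyond the scatter (a 4.0-fold lower number from compound 2 to compound 3 (0.60 log units; beyond the scatter)), so the aromatic carbon next to the ring nitrogen and two ring bonds from the ring sulfur is a position where a single change registers. Going by these compounds alone, the only earlier step concerned the methylsulfanyl group on a different carbon and raised the number (a 3.0-fold higher number from compound 1 to compound 2 (0.48 log units; beyond the scatter)), whereas this one lowers it, so single changes to this core can move the number in either direction. Nothing available accounts for the size or direction of this change.

The compounds shown offer only methyl and hydrogen at this carbon, leaving open how a chlorine, an amine or a longer chain would read here. They also leave open whether the methylsulfanyl step would look the same without the ring methyl.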